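From Pyridin-2-yl to Pyrimidin-2-yl: Expected Solubility

A few compounds are considered here, and "the series" means these few. Any claim that something is new, unique, unknown or untested is made for them only; others in the source may bear on it.

Compound 1 `Clc1ccc(Nc2nc(-c3ccccn3)cs2)nc1` was tested in a physicochemical assay for solubility, in phosphate buffer, with a stated time of 2 h, at pH 7.4; a higher number here means a more soluble compound, a lower number a less soluble compound. In this assay compound 1 gives < 10000 nM, which is a limit of the assay rather than a number. Compound 2 `COc1cccc(-c2csc(Nc3ccc(Cl)cn3)n2)n1` carries a methoxy in place of hydrogen on an aromatic carbon. In this assay compound 2 gives < 10000 nM, again a limit rather than a number. Among the measured compounds shown here, the step that the two limits leave unreadable from compound 1 to compound 2 is therefore not readable, and the only evidence is the limit of < 10000 nM in this assay, at which 2 of the 2 values shown sit. Compound 3 `Clc1ccc(Nc2nc(-c3ncccn3)cs2)nc1` differs from compound 1 by pyrimidin-2-yl in place of pyridin-2-yl on an aromatic carbon. No measured step bears on this change, and compound 1 itself offers only a limit, so the size of the step into compound 3 cannot be read from what is shown. For compound 3 the solubility is expected to be 6000 nM, lying between 1500 nM and 20000 nM. The step that the limit leaves unreadable from compound 1 to compound 3 is thus expected to stay small, with a fair chance that only a limit is reported again.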

Compound 3, solubility: 20000 nM
Compound 3: the middle estimate sits 3.3-fold (0.52 log units) below what was measured; measured number inside the range.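

In this assay compound 3 gives the first value shown that is a number rather than a limit, so this position now has a firm reading. Compound 1 gives < 10000 nM, which is a limit and not a number. Placing pyrimidin-2-yl in place of pyridin-2-yl on this aromatic carbon therefore gives an at least 2.0-fold higher number from compound 1 to compound 3 (0.30 log units; that floor lies within the scatter), so the change may be larger than that floor, but what can be read does not go beyond ordinary scatter.

From the compounds shown here alone, the step from compound 1 to compound 2 still cannot be read, and the size of any step starting from compound 1 stays hidden: the limit of < 10000 nM in this assay, at which 2 of the 3 values shown sit. Also open is how a different group at this position, such as an amine or a carboxylic acid, would read in this assay.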